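This account rests on a few compounds, and the source may have more. Where it says the series, first, only, none or still open, it means among the compounds named here.

Measured in a physicochemical assay for solubility, read by nephelometry, in phosphate buffer, measured as kinetic solubility, at pH 7.4 (on this read-out higher numbers stand for higher solubility and lower numbers for lower solubility), so far:
Compound 1 `C=CC(=O)Nc1ccc(-n2nc3c(=O)[nH]nc(N)c3c2-c2oc3ccc(Cl)cc3c2C)cc1` gives 20000 nM
Compound 2 `Cc1c(-c2c3c(N)n[nH]c(=O)c3nn2-c2ccc(NC(=O)/C=C/CN(C)C)cc2)oc2ccc(Cl)cc12` gives 200000 nM

Of these two measurements, compound 2 stands highest at 200000 nM, and its nearest neighbour is compound 1 at 20000 nM. Among the measured compounds shown here, the single measured step, a 10-fold higher number from compound 1 to compound 2 (1.00 log units; beyond the scatter), places 3-(dimethylamino)prop-1-en-1-yl in place of vinyl on a carbonyl carbon. Compound 3 `Cc1c(-c2c3c(N)n[nH]c(=O)c3nn2-c2ccc(NC(=O)/C=C/CN(C)C)cc2)oc2ccc(Br)cc12` keeps that group and departs from compound 2 in one place: bromo in place of chloro on an aromatic carbon. The step between compound 1 and compound 2 lies elsewhere in the structure, so it bears on this change only weakly and offers no measure of its size. For the measured compounds named here, no measured pair here exchanges one halogen for another, and the direction of any shift in this assay remains open. A change within the usual scatter is therefore expected, and the expected step, a 1.3-fold lower number from compound 2 to compound 3 (0.12 log units; within the scatter), is small. For compound 3 the estimated value is 150000 nM, with an expected range from 60000 nM to 250000 nM.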

Compound 3, solubility: 50000 nM
Estimate against measurement, compound 3: 3.0-fold (0.48 log units) above; the whole stated range lies above it.
By their numbers in this assay, from the lowest: compound 1; then compound 3; then compound 2.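

In this assay, the aromatic carbon that is meta to a fused ring and para to a fused ring proves sensitive to the identity of its halogen: bromo in place of chloro gives a 4.0-fold lower number from compound 2 to compound 3 (0.60 log units; beyond the scatter), a step beyond the scatter. Among the compounds shown here, the only earlier step, a 10-fold higher number from compound 1 to compound 2 (1.00 log units; beyond the scatter), lay elsewhere in the structure, on a carbonyl carbon, so this is the first measured step at the halogen position, and it runs towards a lower number with 3-(dimethylamino)prop-1-en-1-yl held constant. Nothing available here accounts for the size or direction of this shift.

The compounds shown leave open how fluoro, a methoxy group, a nitrile or plain hydrogen would read at this position, since chloro and bromo are the only two groups seen there. They also leave open whether bromo in place of chloro would give a step of similar size and the same direction if vinyl stood on the carbonyl carbon in place of 3-(dimethylamino)prop-1-en-1-yl.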